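The source may report more compounds than this note shows. Statements on the series, on what has been measured and on what is new or still open speak of the compounds shown alone.

The measured compounds:
compound 1 `COc1ccc2c(=O)c(/C=C/C(=O)Nc3cc(C)ccc3C)coc2c1` with > 100000 nM
compound 2 `COc1ccc2c(=O)c(/C=C/C(=O)Nc3ccccc3)coc2c1` with 14000 nM
compound 3 `O=C(/C=C/c1coc2cc(O)ccc2c1=O)NCc1ccccc1` with 63000 nM

Of the compounds shown here, three built on one shared core have been tested in a functional assay (QGY7701 cells, Homo sapiens) for inhibition, read by MTT assay, with a stated time of 48 h; a lower number here means a stronger inhibitor, a higher number a weaker inhibitor. Compound 1 `COc1ccc2c(=O)c(/C=C/C(=O)Nc3cc(C)ccc3C)coc2c1` gives only a limit, > 100000 nM, and not a number. Its reading sits at the limit of > 100000 nM in this assay, at which 1 of the 3 values shown sits, so compound 1 stands at the weak end of what is shown, with no value of its own to anchor a step. Compound 2 `COc1ccc2c(=O)c(/C=C/C(=O)Nc3ccccc3)coc2c1` gives 14000 nM. Compound 3 `O=C(/C=C/c1coc2cc(O)ccc2c1=O)NCc1ccccc1` differs from compound 1 in several places. In this assay compound 3 gives 63000 nM. Within the data shown here, no single-point step links compound 3 to either other compound, so only its value itself can be set beside theirs.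

Compound 4 `COc1ccc2c(=O)c(/C=C/C(=O)NCc3ccccc3F)coc2c1` differs from compound 1 by 2-fluorobenzyl in place of 2,5-dimethylphenyl on an amide-type nitrogen. Among the measured compounds shown here, the one measured step that bears on this change is an at least 7.1-fold lower number from compound 1 to compound 2 (0.85 log units; beyond the scatter), where the 2,5-dimethylphenyl gave way to a phenyl and the number moved beyond the scatter. Compound 4 likewise removes the 2,5-dimethylphenyl, so a lower number than the limit of compound 1 is expected in this assay. The value of compound 3, 63000 nM, suggests the gain need not match that of compound 2. Compound 4 is therefore expected at 40000 nM, with a range from 10000 nM to 150000 nM. The expected step is an at least 2.5-fold lower number from compound 1 to compound 4 (0.39 log units; beyond the scatter).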

Compound 4, half-maximal inhibitory concentration: 34000 nM
Compound 4: middle estimate off by 1.2-fold (0.07 log units), on the high side; low and high end bracket the measured number.
By their numbers in this assay, from the lowest: compound 2; then compounds 4 and 3 (each within the scatter of the next). At a limit, above all of these: compound 1.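

In this assay, compound 4 shows that the phenyl of compound 2 is not the only replacement for the 2,5-dimethylphenyl on this amide-type nitrogen that gives a number rather than a limit: the 2-fluorobenzyl does so too, with an at least 2.9-fold lower number from compound 1 to compound 4 (0.46 log units; beyond the scatter). From the compounds shown here alone, the size of that step remains open-ended, since the reading of compound 1 is a limit and not a number: the limit of > 100000 nM in this assay, at which 1 of the 4 values shown sits. The two replacements do not read alike, and the 2-fluorobenzyl gives the weaker inhibition of the pair, with a 2.4-fold higher number from compound 2 to compound 4 (0.39 log units; beyond the scatter), the only listed comparison on this nitrogen in which both compounds have numbers.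

Among these compounds, whether the fluorine or the extra carbon that links the ring to the nitrogen sets compound 4 apart from compound 2 stays open, and compound 3, which carries a plain benzyl, differs from compound 4 in more than one place and so gives no step. The compounds shown also leave open how an amine or a carboxylic acid on the aromatic ring, or a longer chain on the amide nitrogen, would read in this assay.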